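Methylamino in place of methoxy: outlook for compound 4

The compounds below may be only part of what the source reports. "The series", "measured", "known", "first", "only" and "open" are said of these compounds alone.

Measured so far in a functional assay on HCT-116 cells (Homo sapiens), read by MTT assay, with a stated time of 72 h; a higher number here means a weaker inhibitor, a lower number a stronger inhibitor:
- compound 1 `COc1ncnc2c1c(-c1ccccc1)cn2[C@@H]1O[C@H](CO)[C@@H](O)[C@H]1O` gives > 20000 nM (a limit)
- compound 2 `COc1ncnc2c1c(-c1cc3ccccc3o1)cn2[C@@H]1O[C@H](CO)[C@@H](O)[C@H]1O` gives 13800 nM
- compound 3 `CSc1ncnc2c1c(-c1ccsc1)cn2[C@@H]1O[C@H](CO)[C@@H](O)[C@H]1O` gives > 20000 nM (a limit)

Compound 1 has no number to its name, only a limit (the limit of > 20000 nM in this assay, at which 2 of the 3 values shown sit). Compound 4 `CNc1ncnc2c1c(-c1ccccc1)cn2[C@@H]1O[C@H](CO)[C@@H](O)[C@H]1O` keeps the shared core and the phenyl group of compound 1, with methylamino in place of methoxy on an aromatic carbon, next to the ring nitrogen (methylamino in place of methoxy on an aromatic carbon). Going by the values given here, no measured step changes this substituent alone. Among the compounds with values here, the only measured step (an at least 1.4-fold lower number from compound 1 to compound 2 (0.16 log units; that floor lies within the scatter)) replaces the phenyl group rather than the methoxy, and its floor lies within the scatter. It therefore offers no size for this change, and no step beyond the scatter is expected in this assay. The expected change (an at least 1.2-fold lower number from compound 1 to compound 4 (0.09 log units; that floor lies within the scatter)) is correspondingly small, and a further limit is about as likely as a number. For compound 4 the expected value is 16000 nM, with an estimated range from 5000 nM to 30000 nM.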

Compound 4, half-maximal inhibitory concentration: > 20000 nM
Compound 4: no number, only a limit; the forecaster's own chance of this, stated with the estimate: 55%; middle value at least 1.2-fold (0.09 log units) from the limit.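

In this assay compound 4 gives > 20000 nM, a limit, and compound 1 also has only a limit, so no step between compound 1 and compound 4 can be read: the limit of > 20000 nM in this assay, at which 3 of the 4 values shown sit.

The compounds shown leave open whether methylamino in place of methoxy changes the number at all.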